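This account rests on a few compounds, and the source may have more. Where it says the series, first, only, none or still open, it means among the compounds named here.

Compound 1 `CCCSc1nc(N/N=C/c2ccccc2F)c2nnn(Cc3ccccc3)c2n1` gives > 64000 nM in a functional assay on MCF7 cells (Homo sapiens) for antiproliferative activity, read by MTT assay, with a stated time of 72 h (on this read-out lower numbers stand for stronger inhibition and higher numbers for weaker inhibition), a limit of the assay. Compound 2 `CCCSc1nc(N/N=C/c2ccc(Cl)cc2)c2nnn(Cc3ccccc3)c2n1` gives > 64000 nM in this assay, again a limit. Compound 3 `CCCSc1nc(N/N=C/c2ccc3ccccc3c2)c2nnn(Cc3ccccc3)c2n1` gives > 64000 nM in this assay, also a limit.

Compound 3 therefore stands at the same limit as the other two measured compounds, with no number to place it more precisely; all three share (the limit of > 64000 nM in this assay, at which 3 of the 3 values shown sit). Compound 4 `CCCSc1nc(N/N=C/c2ccccc2)c2nnn(Cc3ccccc3)c2n1` differs from compound 3 in one place: phenyl in place of naphthalen-2-yl on a carbon with a double bond to nitrogen. The measured steps a step that the two limits leave unreadable from compound 1 to compound 3 and a step that the two limits leave unreadable from compound 2 to compound 3, like a step that the two limits leave unreadable from compound 1 to compound 2, give no readable size, so no direction can be drawn from them. Compound 4 is expected to remain at the limit, an estimated step that the limit leaves unreadable from compound 3 to compound 4 that cannot be read as a real change. Compound 4 is estimated at 100000 nM, between 30000 nM and 400000 nM.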

Compound 4, half-maximal inhibitory concentration: > 64000 nM
Compound 4: only a limit was reported (the forecaster's own chance of this, stated with the estimate: 85%); the middle value lies beyond the limit too.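

Within the data shown here, compound 4 sits at the same limit as compound 1, compound 2 and compound 3, so no step among them can be read in this assay: the limit of > 64000 nM in this assay, at which 4 of the 4 values shown sit. The compounds shown leave open whether changing the group on the carbon with a double bond to nitrogen alters activity at all.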